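Aryl exchange on the ring nitrogen of compound 1

A few compounds are considered here, and "the series" means these few. Any claim that something is new, unique, unknown or untested is made for them only; others in the source may bear on it.

Compound 1 `C=CCc1ccc(OCc2cn(-c3ccccc3CO)nn2)c(O)c1` is one of three compounds read in a functional assay on HL-60 cells (Homo sapiens) for inhibition, read by MTT assay, with a stated time of 72 h, tested at 30 uM; a higher number here means more inhibition of growth at the concentration tested, a lower number less inhibition of growth; in it compound 1 gives 31.7%. Compound 2 `C=CCc1cc(O)c(O)c(CN2CCC(CO)CC2)c1` gives 37.7% and compound 3 `C=CCc1cc(O)c(O)c(CN2CCC(CCO)CC2)c1` gives 39.4% in this assay. The number of compound 1 is the lowest of the three, but its gaps to compound 2 and to compound 3 are both within the scatter, so the three compounds cannot be put in order on these numbers.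

Compound 4 `C=CCc1ccc(OCc2cn(-c3ccc(Br)cc3)nn2)c(O)c1` is not yet measured. It differs from compound 1 as follows: 4-bromophenyl in place of 2-(hydroxymethyl)phenyl on an aromatic nitrogen. Among the measured compounds shown here, the only measured step, a number 1.7 percentage points higher from compound 2 to compound 3 (within the scatter), concerns a saturated chain on the core of compound 2 and not the group on the aromatic nitrogen, and it is itself within the scatter; no measured pair bears on the present change. With nothing beyond the three numbers to go on, no step beyond the scatter is expected in this assay, in either direction. Compound 4 is therefore estimated at 32%, with a range from 18% to 46%. The expected step is a number 0.3 percentage points higher from compound 1 to compound 4 (within the scatter), that is, none beyond the scatter.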

Compound 4, percent growth inhibition at one concentration: 22.1%
The estimate for compound 4 lay 9.9 percentage points above the measured number; the measured number falls inside the stated range.
By their numbers in this assay, from the lowest: compounds 4, 1, 2 and 3 (each within the scatter of the next, the first and the last beyond it).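

The first step measured on the aromatic nitrogen, 4-bromophenyl in place of 2-(hydroxymethyl)phenyl, gives in this assay a number 9.6 percentage points lower from compound 1 to compound 4 (within the scatter) and so shows no change beyond the scatter. On this one pair, an exchange that removes the hydroxymethyl group and brings in bromine does not move the number beyond what repeated measurements would give. Nothing on hand explains the size or direction of this step.

The two aryl groups differ both in the substituent and in its place on the phenyl ring, so this single pair cannot separate the two changes. From the compounds shown here alone, it remains open whether unsubstituted phenyl, 2-bromophenyl, 4-(hydroxymethyl)phenyl or an aminophenyl group on the same nitrogen would give a step beyond the scatter in this assay.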